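Swapping fluoro for methyl on the aryl ether of compound 1

The compounds below may be only part of what the source reports. "The series", "measured", "known", "first", "only" and "open" are said of these compounds alone.

The series is a set of macrolide analogues tested in a functional assay on cells for inhibition, with Murine T-cell line (Mus musculus) as the target; a higher number here means a weaker inhibitor, a lower number a stronger inhibitor. Compound 1, `CC[C@@H]1/C=C(\C)C[C@H](C)C[C@H](OC)[C@H]2O[C@@](O)(C(=O)C(=O)N3CCCC[C@H]3C(=O)O[C@H](/C(C)=C/[C@@H]3CC[C@@H](Oc4ccc(F)cc4)[C@H](OC)C3)[C@H](C)[C@@H](O)CC1=O)[C@H](C)C[C@@H]2OC`, gives 3.4 nM there and stands second highest among the three numbers recorded. Compound 2, `CC[C@@H]1/C=C(\C)C[C@H](C)C[C@H](OC)[C@H]2O[C@@](O)(C(=O)C(=O)N3CCCC[C@H]3C(=O)O[C@H](/C(C)=C/[C@@H]3CC[C@@H](O)[C@H](Oc4ccc(OC)cc4)C3)[C@H](C)[C@@H](O)CC1=O)[C@H](C)C[C@@H]2OC`, gives 0.9 nM, a lower number than compound 1 and beyond the scatter. Compound 3, `CC[C@@H]1/C=C(\C)C[C@H](C)C[C@H](OC)[C@H]2O[C@@](O)(C(=O)C(=O)N3CCCC[C@H]3C(=O)O[C@H](/C(C)=C/[C@@H]3CC[C@@H](Oc4cc(C(F)(F)F)cc(C(F)(F)F)c4)[C@H](OC)C3)[C@H](C)[C@@H](O)CC1=O)[C@H](C)C[C@@H]2OC`, gives 607 nM, far higher than compound 1 and also well beyond the scatter; its aromatic ring carries two trifluoromethyl groups, while the other two compounds carry a single small substituent.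

Compound 4, `CC[C@@H]1/C=C(\C)C[C@H](C)C[C@H](OC)[C@H]2O[C@@](O)(C(=O)C(=O)N3CCCC[C@H]3C(=O)O[C@H](/C(C)=C/[C@@H]3CC[C@@H](Oc4ccc(C)cc4)[C@H](OC)C3)[C@H](C)[C@@H](O)CC1=O)[C@H](C)C[C@@H]2OC`, differs from compound 1 in one place: methyl in place of fluoro on an aromatic carbon. Among the measured compounds shown here, no measured pair shows this exact change, so the expected step rests on the closeness of fluoro and methyl in size and on the fact that both remain single substituents. The author expects the step of a 1.2-fold higher number from compound 1 to compound 4 (0.07 log units; within the scatter) to be small, with no confident direction, likely within the scatter. Compound 4 is accordingly estimated at 4 nM, with a range from 1.5 nM to 12 nM.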

Compound 4, half-maximal inhibitory concentration: 2.7 nM
Compound 4: the middle estimate sits 1.5-fold (0.17 log units) above what was measured; low and high end bracket the measured number.
By their numbers in this assay, from the lowest: compound 2; then compounds 4 and 1 (each within the scatter of the next); then compound 3.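

Among the compounds shown here, replacing 4-fluorophenoxy with 4-methylphenoxy on the core of compound 1 gives a 1.3-fold lower number from compound 1 to compound 4 (0.10 log units; within the scatter) in this assay and so provides the first direct reading at this position, on an aromatic carbon para to a large group. Among the compounds shown, fluoro and methyl at this place cannot be told apart, whereas the earlier compounds offered no single-place step that could isolate the effect of either substituent. Nothing available here accounts for this close agreement.

The pair covers only these two single substituents, so it leaves open how an amine, a carboxylic acid or a longer chain such as butyl would read at the same place. It also leaves open whether methyl and fluoro would still match if the rest of the core of compound 1 were changed.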